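This account rests on a few compounds, and the source may have more. Where it says the series, first, only, none or still open, it means among the compounds named here.

Compound 2 `Cc1cccc(C(=O)Nc2cc(-c3ccccc3)nn2-c2ccccc2)c1` is measured in an assay on CHO cells with metabotropic glutamate receptor 5 (Homo sapiens) as the target (a higher number here means that more compound is needed for the effect, a lower number that less compound is needed), at 90 nM. Among the two numbers known this is the higher one, since compound 1 `Cc1ccc(C(=O)Nc2cc(-c3ccccc3)nn2-c2ccccc2)cc1` gives 30 nM in this assay, a step of a 3.0-fold higher number from compound 1 to compound 2 (0.48 log units; beyond the scatter). Compound 3 `O=C(Nc1cc(-c2ccccc2)nn1-c1ccccc1)c1ccc(F)c(F)c1` differs from compound 2 by 3,4-difluorophenyl in place of 3-methylphenyl on a carbonyl carbon. Among the compounds with values here, the single measured step concerns a different change, the shift of a methyl group within the same ring, so it guides only weakly. For compound 3 a step of a 1.5-fold lower number from compound 2 to compound 3 (0.18 log units; within the scatter) is therefore expected, not far beyond the scatter. Compound 3 is estimated at 60 nM, in a range of 15 nM to 250 nM.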

Compound 3, half-maximal effective concentration: 10 nM
Estimate against measurement, compound 3: 6.0-fold (0.78 log units) above; the whole stated range lies above it.
By their numbers in this assay, from the lowest: compound 3; then compound 1; then compound 2.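

With 3,4-difluorophenyl on the carbonyl carbon, the number in this assay drops to the lowest of the three, with a 9.0-fold lower number from compound 2 to compound 3 (0.95 log units; beyond the scatter) and a 3.0-fold lower number from compound 1 to compound 3 (0.48 log units; beyond the scatter). So replacing the methyl-bearing ring with this fluorinated one lowers the amount of compound needed, something the earlier shift of a methyl group could not show. Nothing available explains why this change has this effect.

On these data alone, it remains open whether one fluorine alone would do the same, or how a chlorine, a methoxy group or an amine would compare. As far as these compounds go, all three compounds share the same core, so the effect of changes there also remains open.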